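The source may hold more compounds than are shown below. What is called first, only, known or untested is meant among the compounds shown, and "the series" means these compounds.

Compound 1 `Cc1cc2nn(-c3ccccc3)c(N)c2c(=O)[nH]1`: 5%
Compound 2 `Nc1c2c(=O)[nH]c(-c3ccccc3)cc2nn1-c1ccccc1`: -2%
Compound 3 `Nc1c2c(=O)[nH]c(-c3ccccn3)cc2nn1-c1ccccc1`: 4%

Of the compounds shown here, three built on the same core have been measured in an assay on isolated protein for inhibition of RAC-alpha serine/threonine-protein kinase (Homo sapiens), read by mobility shift assay, tested at 30 uM; a higher number here means more inhibition at the concentration tested (going by the name of the read-out), a lower number less inhibition. Compound 1 gives 5%, compound 2 gives -2% and compound 3 gives 4%. Compound 3 stands second highest of the three numbers, but the steps of a number 1 percentage points lower from compound 1 to compound 3 (within the scatter) and a number 6 percentage points higher from compound 2 to compound 3 (within the scatter) both lie within the scatter, so the three compounds cannot be ordered against each other.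

Compound 4 `COc1ccccc1-c1cc2nn(-c3ccccc3)c(N)c2c(=O)[nH]1` differs from compound 3 in one place: 2-methoxyphenyl in place of pyridin-2-yl on an aromatic carbon. The measured steps that bear on this change are the earlier exchanges at the same aromatic carbon: a number 7 percentage points lower from compound 1 to compound 2 (within the scatter), a number 1 percentage points lower from compound 1 to compound 3 (within the scatter) and a number 6 percentage points higher from compound 2 to compound 3 (within the scatter). None of them moved the read-out beyond the scatter, whether the group there was methyl, a six-membered aromatic ring of carbon only, or a six-membered aromatic ring with 1 hetero atom. For compound 4, therefore, no step beyond the scatter is expected in this assay. The estimate for compound 4 is 3%, with a range from -10% to 16%. The expected step is a number 1 percentage points lower from compound 3 to compound 4 (within the scatter).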

Compound 4, a percentage reported as inhibition, at one concentration (the size of the read-out at that concentration, not a potency): 15%
For compound 4 the middle estimate is 12 percentage points below the measured one; the measured number falls inside the stated range.
By their numbers in this assay, from the lowest: compounds 2, 3, 1 and 4 (each within the scatter of the next, the first and the last beyond it).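

Going by these compounds alone, this is the first exchange at this aromatic carbon, next to the ring nitrogen, to carry the read-out in this assay beyond the scatter: 2-methoxyphenyl in place of pyridin-2-yl gives a number 11 percentage points higher from compound 3 to compound 4 (beyond the scatter), and methoxy in place of hydrogen on the phenyl group gives a number 17 percentage points higher from compound 2 to compound 4 (beyond the scatter). Against methyl the change gives only a number 10 percentage points higher from compound 1 to compound 4 (within the scatter), so 2-methoxyphenyl is set apart from the two unsubstituted aromatic rings but not from the small group of compound 1. Nothing at hand explains this difference.

Still open, going by these compounds, is whether methoxy is needed on that phenyl group, or whether an amine, a carboxylic acid or a longer chain there would read the same. The position of the methoxy group on that ring also remains an open question.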